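The source may report more compounds than this note shows. Statements on the series, on what has been measured and on what is new or still open speak of the compounds shown alone.

Notes on the series. Compound 1 `Oc1cccc(Nc2nc(NCc3ccccc3)c3ccccc3n2)c1` is the reference point. In a functional assay on SK-MEL-2 cells (Homo sapiens) for inhibition, read by MTT assay, tested at 100 uM (a lower number here means less inhibition, a higher number more inhibition at the concentration tested (going by the name of the read-out)), compound 1 gives 78.9%, the highest of the two numbers obtained so far. Compound 2 `O=[N+]([O-])c1cccnc1Sc1ccccc1NS(=O)(=O)c1ccc(Cl)cc1Cl` gives 40.1% in this assay, a gap below compound 1 that lies beyond the scatter. Compound 3 `Fc1ccc(Nc2nc(NCc3ccccc3)c3ccccc3n2)cc1` has not yet been measured in this assay. It differs from compound 1 in one place: 4-fluorophenyl in place of 3-hydroxyphenyl on a nitrogen on an aromatic ring. Within the data shown here, no measured pair shows this change, so the step is expected to be modest and downward, a number 13.9 percentage points lower from compound 1 to compound 3 (beyond the scatter). For compound 3 the expected value in this assay is 65%, within a range from 40% to 85%.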

Compound 3, a percentage reported as inhibition, at one concentration (the size of the read-out at that concentration, not a potency): 89.9%
Compound 3: the middle estimate sits 24.9 percentage points below what was measured, and the stated range ends below it.
By their numbers in this assay, from the lowest: compound 2; then compound 1; then compound 3.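

On the nitrogen on an aromatic ring, 4-fluorophenyl in place of 3-hydroxyphenyl raises the number in this assay, a number 11 percentage points higher from compound 1 to compound 3 (beyond the scatter). Inhibition at the concentration tested therefore does not depend on keeping the 3-hydroxyphenyl group at this position. No available evidence accounts for the rise.

The step changes both the substituent and its number on the ring, so 4-hydroxyphenyl and 3-fluorophenyl would be needed to separate the two. On these data alone, whether plain phenyl or 4-methoxyphenyl on the same nitrogen keeps this level also remains open.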